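Cyclopentanediol acrylamides: para substituent swap on the anilide

A few compounds are considered here, and "the series" means these few. Any claim that something is new, unique, unknown or untested is made for them only; others in the source may bear on it.

Measured so far in an ADME assay on S2 cells (Drosophila melanogaster) for cytotoxicity, read by MTT assay; on this read-out higher numbers stand for an effect only at larger amounts of compound and lower numbers for an effect already at smaller amounts:
- compound 1, `O=C(/C=C/[C@H]1C[C@@H](O)[C@@H](O)C1)Nc1ccc(Cl)cc1`: > 180000 nM
- compound 2, `O=C(/C=C/[C@H]1C[C@@H](O)[C@@H](O)C1)Nc1ccc([N+](=O)[O-])cc1`: > 170000 nM

In this assay compound 1 reaches only the limit of the assay, > 180000 nM, not a number. Compound 2 likewise reaches only the limit of the assay, > 170000 nM, not a number. The step from compound 1 to compound 2, nitro in place of chloro on an aromatic carbon, is therefore a step that the two limits leave unreadable from compound 1 to compound 2; neither the limit of > 170000 nM in this assay, at which 1 of the 2 values shown sits, nor the limit of > 180000 nM in this assay, at which 1 of the 2 values shown sits, gives a size for it, and both compounds stand at the top of the measured range with nothing above them.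

Compound 3, `CN(C)c1ccc(NC(=O)/C=C/[C@H]2C[C@@H](O)[C@@H](O)C2)cc1`, carries the change (dimethylamino in place of nitro on an aromatic carbon).

Only the unreadable step from compound 1 to compound 2 bears on this change, and it gives no size. Both anilides shown sit at the limit of the assay, so no step beyond the scatter is expected in this assay from compound 2 to compound 3, and the estimated step that the limit leaves unreadable from compound 2 to compound 3 rests on the two limits alone. Compound 3 is expected to give about 200000 nM, in a range from 80000 nM to 500000 nM, most likely reported again as a limit rather than a number.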

Compound 3, half-maximal effective concentration: > 170000 nM
Compound 3 ended at the assay's limit (the forecaster's own chance of this, stated with the estimate: 85%); the middle value does not contradict the limit.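

No new step can be read in this assay: compound 1, compound 2 and compound 3 all stand at limits of the assay, not at numbers, so the steps among them cannot be read. The compounds shown leave open whether chloro, nitro and dimethylamino on the aromatic carbon differ at all in this assay.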